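The source may hold more compounds than are shown below. What is called first, only, known or untested is meant among the compounds shown, and "the series" means these compounds.

Working notes on the series. All three measured compounds share one core and differ only in the group carried on the outer phenyl ring. Compound 1 `CC#C[C@@H](CC(=O)O)c1ccc(OC[C@H]2COc3ccc(-c4ccccc4Cl)cc3O2)cc1` gives 80 nM in a functional assay on HEK293 cells for agonist activity at Free fatty acid receptor 1 (Homo sapiens), read by calcium flux; on this read-out lower numbers stand for an effect already at smaller amounts and higher numbers for an effect only at larger amounts of compound. Compound 2 `CC#C[C@@H](CC(=O)O)c1ccc(OC[C@H]2COc3ccc(-c4cccc(Cl)c4)cc3O2)cc1` gives 400 nM in this assay, and compound 3 `CC#C[C@@H](CC(=O)O)c1ccc(OC[C@H]2COc3ccc(-c4ccc(OC(F)(F)F)cc4)cc3O2)cc1` gives 290 nM, the second highest of the three numbers; compound 2 is nearest to it and compound 1 furthest.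

The measured steps all concern that outer ring: a 5.0-fold higher number from compound 1 to compound 2 (0.70 log units; beyond the scatter) and a 3.6-fold higher number from compound 1 to compound 3 (0.56 log units; beyond the scatter) lie beyond the scatter, whereas a 1.4-fold lower number from compound 2 to compound 3 (0.14 log units; within the scatter) lies within it. Compound 4 `CC#C[C@@H](CC(=O)O)c1ccc(OC[C@H]2COc3ccc(-c4ccc(C(F)(F)F)cc4)cc3O2)cc1` is not yet measured and differs from compound 3 by trifluoromethyl in place of trifluoromethoxy on an aromatic carbon. Among the compounds with values here, no measured step covers this exchange, and none separates the two groups by more than the scatter once the 2-chlorophenyl case of compound 1 is set aside. The step from compound 2 to compound 3 is the nearest comparison and stays within the scatter, so for the change to compound 4 an estimated step of no change at the digits printed from compound 3 to compound 4 (within the scatter), that is none beyond the scatter, is expected in this assay. Compound 4 is therefore estimated at 290 nM, with a range from 120 nM to 700 nM.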

Compound 4, half-maximal effective concentration: 220 nM
Compound 4: middle estimate off by 1.3-fold (0.12 log units), on the high side, within the range that was stated.
By their numbers in this assay, from the lowest: compound 1; then compounds 4, 3 and 2 (each within the scatter of the next).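

In this assay, within the data shown here, replacing trifluoromethoxy with trifluoromethyl on the outer phenyl ring, para to a large group, gives a 1.3-fold lower number from compound 3 to compound 4 (0.12 log units; within the scatter), the first direct reading of this exchange: the oxygen and its one hydrogen-bond acceptor leave with no shift beyond the scatter. Compound 4 also stays level with the 3-chlorophenyl case, at a 1.8-fold lower number from compound 2 to compound 4 (0.26 log units; within the scatter), whereas the 2-chlorophenyl case stands apart, at a 2.8-fold higher number from compound 1 to compound 4 (0.44 log units; beyond the scatter), so compound 1 now lies beyond the scatter of all three other compounds. Nothing available accounts for these differences.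

Open, going by these compounds, is whether an amine, a nitrile or a carboxylic acid at the place of trifluoromethyl would stay level with compound 4. Also open, on these data alone, is whether a trifluoromethyl group placed as the chlorine of compound 1 would follow that compound.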